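Replacing Furan-3-yl with 3-Hydroxyphenyl in Compound 3

This account rests on a few compounds, and the source may have more. Where it says the series, first, only, none or still open, it means among the compounds named here.

Compound 1, `CC(C)N(Cc1cccc(OCCCCCC(=O)O)c1)C(=O)c1ccc(-c2ccoc2)cc1`, and compound 2, `CCOC(=O)CCCCCOc1cccc(CN(C(=O)c2ccc(-c3ccoc3)cc2)C(C)C)c1`, were both examined in an ADME assay on HEK293 cells (Homo sapiens) for cytotoxicity, read by CellTiter-Glo and resazurin assay, with a stated time of 72 h; on this read-out higher numbers stand for an effect only at larger amounts of compound and lower numbers for an effect already at smaller amounts. Compound 1 reached only the assay limit of > 26000 nM. Compound 2 likewise returned only the limit of > 26000 nM. The step that the two limits leave unreadable from compound 1 to compound 2 therefore cannot be given a size, because both values rest at the limit of > 26000 nM in this assay, at which 2 of the 2 values shown sit. Compound 3, `CCOC(=O)CCCCCOc1cccc(CN(C(=O)c2ccc(-c3cccc(O)c3)cc2)C(C)C)c1`, carries 3-hydroxyphenyl in place of furan-3-yl on an aromatic carbon. Among the measured compounds shown here, no measured step touches that kind of change, and the single recorded step is unreadable, so the account rests on the two limits alone. The step that the limit leaves unreadable from compound 2 to compound 3 is expected to stay within the usual scatter in either direction. Compound 3 is estimated to give 30000 nM, with a range from 12000 nM to 80000 nM, and it is expected most likely to sit again at the limit rather than at a readable number.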

Compound 3, half-maximal effective concentration: > 26000 nM
Compound 3 gave a limit, no number; the forecaster's own chance of this, stated with the estimate: 70%; the middle value is on the limit's open side.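

In this assay, compound 2 and compound 3 each gave only a limit, so no step between them can be read: the limit of > 26000 nM in this assay, at which 3 of the 3 values shown sit.

The compounds shown leave open whether the change from furan-3-yl to 3-hydroxyphenyl alters cytotoxicity, and at what concentration any of them would produce an effect.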